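The source may report more compounds than this note shows. Statements on the series, on what has been measured and on what is new or still open speak of the compounds shown alone.

Measured compounds and their values:
compound 1 `Cn1cc(SCc2nnc(SCc3ccccc3)n2-c2c(Cl)cccc2Cl)c2ccccc21`: > 100000 nM
compound 2 `Cn1cc(SCc2nnc(SCc3ccc(Cl)cc3Cl)n2-c2c(Cl)cccc2Cl)c2ccccc21`: > 100000 nM
compound 3 `Cn1cc(SCc2nnc(SCc3cc(Cl)ccc3F)n2-c2c(Cl)cccc2Cl)c2ccccc21`: > 100000 nM

In a toxicity assay on HEK-293T cells (Homo sapiens) for cytotoxicity, read by CCK-8 assay, with a stated time of 48 h (on this read-out higher numbers stand for lower toxicity in this test and lower numbers for higher toxicity in this test), compound 1 sits at a limit of the assay, not a number. Compound 2 also sits at a limit. Compound 3 likewise sits at a limit, so its standing on the numbers shown is only that it lies at the limit of > 100000 nM in this assay, at which 3 of the 3 values shown sit. The three steps among them, a step that the two limits leave unreadable from compound 1 to compound 2, a step that the two limits leave unreadable from compound 1 to compound 3 and a step that the two limits leave unreadable from compound 2 to compound 3, are therefore unreadable in size. Compound 4 `Cn1cc(SCc2nnc(SCc3ccc(Cl)cc3C(F)(F)F)n2-c2c(Cl)cccc2Cl)c2ccccc21` differs from compound 3 by 4-chloro-2-(trifluoromethyl)phenyl in place of 5-chloro-2-fluorophenyl on a saturated chain carbon bound to a sulfur. All three measured steps bear on this change only in that none of them moved a value off the limit. The step from compound 3 to compound 4 is expected to be a number no higher from compound 3 to compound 4 (the limit leaves the size open), no readable step in either direction. Compound 4 is expected to give 100000 nM, between 50000 nM and 300000 nM.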

Compound 4, half-maximal cytotoxic concentration: 56500 nM
Estimate against measurement, compound 4: 1.8-fold (0.25 log units) above, within the range that was stated.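

In this assay compound 4, with 4-chloro-2-(trifluoromethyl)phenyl on the saturated chain carbon bound to a sulfur, alone gives a number and not a limit, while the steps among compound 1, compound 2 and compound 3 cannot be read: the limit of > 100000 nM in this assay, at which 3 of the 4 values shown sit.

The change now reads as an at least 1.7-fold lower number from compound 3 to compound 4 (0.24 log units; that floor lies within the scatter), as an at least 1.7-fold lower number from compound 1 to compound 4 (0.24 log units; that floor lies within the scatter) and, with trifluoromethyl in place of chloro on an aromatic carbon, as an at least 1.7-fold lower number from compound 2 to compound 4 (0.24 log units; that floor lies within the scatter).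

As far as these compounds go, how far these steps go beyond their floors stays open, as does what an amine or a carboxylic acid at this place would give.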